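This account rests on a few compounds, and the source may have more. Where it says the series, first, only, none or still open, it means among the compounds named here.

Compound 2 `Nc1sc(-c2ccc([N+](=O)[O-])cc2)c(-c2cccc(C(F)(F)F)c2)c1C(=O)c1ccccc1` stands only at a limit in a functional assay on CHO-K1 cells for agonist activity at adenosine receptor A1 (Homo sapiens), read by GTPgammaS binding; on this read-out lower numbers stand for an effect already at smaller amounts and higher numbers for an effect only at larger amounts of compound: there compound 2 gives > 10 uM, which is a limit of the assay and not a number. Compound 1 `CC(=O)c1cccc(-c2sc(N)c(C(=O)c3ccccc3)c2-c2cccc(C(F)(F)F)c2)c1` likewise reaches only a limit, giving > 10 uM in this assay. The step that the two limits leave unreadable from compound 1 to compound 2 therefore cannot be read. Compound 3 `Nc1sc(-c2ccc(Cl)cc2)c(-c2cccc(C(F)(F)F)c2)c1C(=O)c1ccccc1` differs from compound 2 by chloro in place of nitro on an aromatic carbon. No readable measured step bears on this change; what exists is the limit of > 10 uM in this assay, at which 2 of the 2 values shown sit. Compound 3 is thus expected to remain near that limit, with an estimated step that the limit leaves unreadable from compound 2 to compound 3. The estimate for compound 3 is 20 uM, between 5 uM and 100 uM.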

Compound 3, concentration for half-maximal effect: > 10 uM
Compound 3: only a limit was reported; the forecaster's own chance of this, stated with the estimate: 75%; the middle value does not contradict the limit.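

In this assay, within the data shown here, compound 3 gives > 10 uM, which is a limit and not a number, so no step from compound 1 or compound 2 to it can be read. The compounds shown leave open whether 3-acetylphenyl, 4-nitrophenyl and 4-chlorophenyl differ at all in this assay.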